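The source may hold more compounds than are shown below. What is called first, only, known or untested is meant among the compounds shown, and "the series" means these compounds.

Working notes on the chalcone set in a functional assay on CCRF-CEM cells (Homo sapiens) for cytotoxicity, with a stated time of 72 h; on this read-out higher numbers stand for weaker inhibition and lower numbers for stronger inhibition.

Compound 1 `C#CCOc1ccc(C(CC(=O)c2cccc(C)c2)CC(=O)c2cccc(C)c2)cc1OC` carries two ketone arms on one benzylic carbon. In this assay compound 1 gives only a limit, > 50000 nM, so no number stands for it. the limit of > 50000 nM in this assay, at which 1 of the 3 values shown sits, is the only such entry in the set.

Compound 2 `C#CCOc1ccc(/C=C/C(=O)c2cccc(C)c2)cc1OC` is the single-arm enone. In this assay compound 2 gives 8820 nM. Compound 3 `C=CCc1cc(C(C)=O)ccc1OCC=C(C)C` is the allyl-bearing acetophenone ether; in this assay compound 3 gives 16300 nM. The values of compound 2 and compound 3 lie within the scatter of each other, so neither can be called stronger; compound 2 simply holds the lower of the two numbers that were obtained.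

Compound 4 `C#CCOc1ccc(/C=C/C(=O)c2cccn2C)cc1OC` keeps the enone and ether side of compound 2 and differs only at the aryl end of the ketone: 1-methyl-1H-pyrrol-2-yl in place of 3-methylphenyl on a carbonyl carbon. Going by the values given here, no measured pair of this kind exists in the set, so the direction of the step is not anchored by data. The expectation is a step of modest size from compound 2 to compound 4, a 1.4-fold higher number from compound 2 to compound 4 (0.13 log units; within the scatter), and not one clearly beyond the scatter. Compound 4 is estimated at 12000 nM, with the likely range running from 4000 nM to 40000 nM.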

Compound 4, half-maximal inhibitory concentration: > 50000 nM
Compound 4 gave a limit, no number; the forecaster's own chance of this, stated with the estimate: 10%; middle value at least 4.1-fold (0.61 log units) from the limit.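

In this assay the aryl end of the ketone proves sensitive to change: 1-methyl-1H-pyrrol-2-yl in place of 3-methylphenyl on a carbonyl carbon gives an at least 5.6-fold higher number from compound 2 to compound 4 (0.75 log units; beyond the scatter). Going by these compounds, the value of compound 4, > 50000 nM, is a limit and not a number, so this step has a lower bound only and its full size stays unknown. Until now the only entry at a limit was compound 1 with its two ketone arms, whereas compound 4 shows that a single-arm enone can sit there too, so the single enone and ether side shared by compound 2 and compound 4 is not enough to keep a measurable value: the limit of > 50000 nM in this assay, at which 2 of the 4 values shown sit.

The compounds shown do not separate the parts of this change, since the ring size, the ring nitrogen and the methyl on that ring all differ at once between the two aryl groups. On these data alone, an unsubstituted phenyl or a 1H-pyrrol-2-yl lacking the methyl at the same carbonyl carbon would be needed to tell these apart, and the answer remains open for now.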